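This account rests on a few compounds, and the source may have more. Where it says the series, first, only, none or still open, it means among the compounds named here.

In a physicochemical assay for metabolic stability, read by LC-MS, in phosphate buffer, with a stated time of 3 h, at pH 7.4, tested at 50 uM (a lower number here means that less of the compound is left, a higher number that more of the compound is left), compound 2, `CC(C)OC(=O)OCOC(=O)C1=C(S[C@@H]2CN[C@H](C(=O)Nc3cccc(C(=O)O)c3)C2)[C@H](C)[C@@H]2[C@@H]([C@@H](C)O)C(=O)N12`, gives > 95%, and this is a limit of the assay rather than a number. Compound 1, `CCOC(=O)OCOC(=O)C1=C(S[C@@H]2CN[C@H](C(=O)Nc3cccc(C(=O)OCOC(=O)OCC)c3)C2)[C@H](C)[C@@H]2[C@@H]([C@@H](C)O)C(=O)N12`, is the other compound shown, and in this assay compound 1 gives > 95%, again a limit. Compound 3, `CCOC(=O)OCOC(=O)C1=C(S[C@@H]2CN[C@H](C(=O)Nc3cccc(C(=O)O)c3)C2)[C@H](C)[C@@H]2[C@@H]([C@@H](C)O)C(=O)N12`, differs from compound 2 by hydrogen in place of methyl on a saturated chain carbon bound to an oxygen next to a carbonyl group and a saturated chain carbon, so that isopropoxycarbonyl becomes ethoxycarbonyl. Within the data shown here, no measured pair of compounds that differ in one place exists here, so no step size can be read off directly. The expected step that the limit leaves unreadable from compound 2 to compound 3 is none beyond the scatter, as compound 1 already carrying ethoxycarbonyl groups sits at the limit of > 95% in this assay, at which 2 of the 2 values shown sit. Compound 3 is therefore expected to remain at 97%, within a range from 90% to 100%.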

Compound 3, percent of the compound remaining: > 95%
Compound 3 ended at the assay's limit; the forecaster's own chance of this, stated with the estimate: 85%; the middle value is on the limit's open side.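

No step can be read from compound 2 to compound 3 or from compound 1 to compound 3 in this assay, since all three results are limits and not numbers: the limit of > 95% in this assay, at which 3 of the 3 values shown sit.

The compounds shown leave open whether isopropoxycarbonyl, ethoxycarbonyl and ((ethoxycarbonyl)oxy)methyl differ at all in this assay.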